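Chloro in place of trifluoromethyl on the shared core

The compounds below may be only part of what the source reports. "The series", "measured", "known", "first", "only" and "open" are said of these compounds alone.

Measured so far in an assay on Jurkat cells for activation of nuclear factor NF-kappa-B complex (Homo sapiens); on this read-out higher numbers stand for weaker inhibition and lower numbers for stronger inhibition:
compound 1 `Cc1nc(Cl)ncc1C(=O)Nc1cc(C(F)(F)F)cc(C(F)(F)F)c1`: 50 nM
compound 2 `O=C(Nc1cc(C(F)(F)F)cc(C(F)(F)F)c1)c1cnc(Cl)nc1`: 300 nM
compound 3 `O=C(Nc1cc(C(F)(F)F)cc(C(F)(F)F)c1)c1cc(C(F)(F)F)nc(Cl)n1`: > 10000 nM

Compound 3 sits at the assay limit (the limit of > 10000 nM in this assay, at which 1 of the 3 values shown sits), so its entry is a limit and not a number. Compound 2, the core without the trifluoromethyl group, gives 300 nM in this assay. Compound 4 `O=C(Nc1cc(C(F)(F)F)cc(C(F)(F)F)c1)c1cc(Cl)nc(Cl)n1` is the next member: chloro in place of trifluoromethyl on an aromatic carbon. Going by the values given here, the only measured step, a 6.0-fold higher number from compound 1 to compound 2 (0.78 log units; beyond the scatter), concerns a different position and does not bear directly on this change; no measured step covers chloro at this site. From the gap between compound 2 and the limit of compound 3, compound 4 is expected to land between them, with the step of an at least 3.3-fold lower number from compound 3 to compound 4 (0.52 log units; beyond the scatter) estimated in this assay. Compound 4 is expected at about 3000 nM, in the range 500 nM to 10000 nM.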

Compound 4, half-maximal inhibitory concentration: > 10000 nM
Compound 4 ended at the assay's limit; the forecaster's own chance of this, stated with the estimate: 35%; middle value at least 3.3-fold (0.52 log units) away from the limit.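

Swapping trifluoromethyl for chloro on this aromatic carbon gives no readable value in this assay, so the loss of inhibition is not tied to trifluoromethyl alone, and the step between compound 3 and compound 4 cannot be read, as both entries are limits: the limit of > 10000 nM in this assay, at which 2 of the 4 values shown sit.

The 2,6-dichloropyrimidin-4-yl group on the carbonyl carbon gives an at least 33-fold higher number from compound 2 to compound 4 (1.52 log units; beyond the scatter), and an at least 200-fold higher number from compound 1 to compound 4 (2.30 log units; beyond the scatter).

Neither step separates the chloro at this site from the other differences in the ring. Going by these compounds, whether an amine or a methoxy group on this aromatic carbon gives a readable value stays open.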